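The source may hold more compounds than are shown below. What is called first, only, known or untested is meant among the compounds shown, and "the series" means these compounds.

The series shares one core; compound 1 `CCOc1cccc2cc(-c3ccccc3)c(=O)oc12` carries an unsubstituted phenyl ring, and in an assay on CHO cells for displacement of a labelled ligand from adenosine receptor A1 (Homo sapiens), read by radioligand binding (on this read-out higher numbers stand for weaker inhibition and lower numbers for stronger inhibition), compound 1 gives 22100 nM. Compound 2 `CCOc1cccc2cc(-c3ccc(Br)cc3)c(=O)oc12` adds a bromo group to that ring. In this assay compound 2 reaches only the limit of the assay, > 100000 nM. Compound 3 `O=c1oc2c(O)cccc2cc1-c1ccc(Br)cc1` is likewise read only as a limit in this assay, giving > 100000 nM. The step of an at least 4.5-fold higher number from compound 1 to compound 2 (0.65 log units; beyond the scatter) is therefore a weakening, whereas a step that the two limits leave unreadable from compound 2 to compound 3 cannot be read because both values sit at the limit of > 100000 nM in this assay, at which 2 of the 3 values shown sit. Compound 2 thus stands at the limit rather than at a number, and only compound 1 shows a measured figure.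

Compound 4 `CCOc1cccc2cc(-c3ccc(OC)cc3)c(=O)oc12` differs from compound 2 by methoxy in place of bromo on an aromatic carbon. Of the measured steps only an at least 4.5-fold higher number from compound 1 to compound 2 (0.65 log units; beyond the scatter) bears on this change: that step introduced the bromo group, and the change to compound 4 removes it again. Among the measured compounds shown here, the methoxy group has no measured counterpart. A return toward compound 1 is expected, so the step of an at least 2.5-fold lower number from compound 2 to compound 4 (0.39 log units; beyond the scatter) is estimated to lower the number in this assay. Compound 4 is expected at 40000 nM, within 12000 nM to 150000 nM.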

Compound 4, inhibition constant: > 100000 nM
Compound 4: a limit, no number; the forecaster's own chance of this, stated with the estimate: 45%; at least 2.5-fold (0.39 log units) between middle value and limit.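

Methoxy in place of hydrogen, para to a large group, gives an at least 4.5-fold higher number from compound 1 to compound 4 (0.65 log units; beyond the scatter), so a weakening at this position in this assay is no longer seen with bromo alone. Compound 4 gives > 100000 nM, which is a limit and not a number. Bromo and methoxy cannot be ranked against each other, and the step between them cannot be read, because both compounds sit at the same limit: the limit of > 100000 nM in this assay, at which 3 of the 4 values shown sit.

Going by these compounds, whether any group at this position gives a lower number than the unsubstituted phenyl ring stays open, and a fluoro group, an amine or a carboxylic acid there would test this. Among the compounds shown here, the only pair with hydrogen in place of ethyl on the oxygen stands at limits on both sides, so what that change does with the unsubstituted phenyl ring also stays open.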